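This account rests on a few compounds, and the source may have more. Where it says the series, first, only, none or still open, it means among the compounds named here.

Of the compounds shown here, two sharing one core have been measured in a functional assay on HL-60 cells (Homo sapiens) for antiproliferative activity, with a stated time of 48 h; a higher number here means a weaker inhibitor, a lower number a stronger inhibitor. Compound 1 (`Cc1ccc(/C=N/NC(=S)N2CCNCC2)cc1`) gives 70000 nM, the highest of the two numbers, while compound 2 (`C/C(=N\NC(=S)N1CCNCC1)c1ccc(O)cc1`) gives 60000 nM; the two lie within the scatter of one another, so neither can be called the weaker inhibitor. Compound 3 (`S=C(N/N=C/c1ccccc1)N1CCNCC1`) has not been measured. It differs from compound 1 by hydrogen in place of methyl on an aromatic carbon. Among the measured compounds shown here, no measured step of this kind exists here to guide the guess, so in this assay the change is expected to be a 1.1-fold higher number from compound 1 to compound 3 (0.06 log units; within the scatter), a shift that stays inside the scatter. Compound 3 is therefore expected to give 80000 nM, within a range from 40000 nM to 160000 nM.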

Compound 3, half-maximal inhibitory concentration: 63000 nM
The estimate for compound 3 lay 1.3-fold (0.10 log units) above the measured number; the range from low to high includes it.
By their numbers in this assay, from the lowest: compounds 2, 3 and 1 (each within the scatter of the next).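

In this assay, among the compounds shown here, putting hydrogen in place of methyl on the aromatic carbon para to a large group gives a 1.1-fold lower number from compound 1 to compound 3 (0.05 log units; within the scatter) and is the first single change that can be read. At this position, the methyl group can therefore be removed without a shift that stands out from the scatter. Nothing available here offers an explanation for this result.

Only hydrogen and methyl can be compared at this position. From the compounds shown here alone, whether an amine, a carboxylic acid or a longer chain placed there would move the number beyond the scatter remains open.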